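A few compounds are considered here, and "the series" means these few. Any claim that something is new, unique, unknown or untested is made for them only; others in the source may bear on it.

Compound 3 `C#CCN1CCN(CC(=O)N2CCN(c3ccc(C(=O)c4cc5ccc(N(CC)CC)cc5o4)cc3)CC2)CC1` in a functional assay on HeLa cells (Homo sapiens) for cytotoxicity, read by MTT assay, with a stated time of 48 h (a lower number here means a stronger inhibitor, a higher number a weaker inhibitor), gives > 40000 nM, which is a limit of the assay rather than a number. Compound 1 `CCN(CC)c1ccc2cc(C(=O)c3ccc(N4CCN(C(=O)CN5CCN(S(=O)(=O)c6ccc(OC(F)(F)F)cc6)CC5)CC4)cc3)oc2c1` in this assay gives 30200 nM. Compound 2 `CCN(CC)c1ccc2cc(C(=O)c3ccc(N4CCN(C(=O)CN5CCN(S(=O)(=O)c6ccc(C(F)(F)F)cc6)CC5)CC4)cc3)oc2c1` gives > 40000 nM, again a limit. The step of an at least 1.3-fold higher number from compound 1 to compound 2 (0.12 log units; that floor lies within the scatter) has its floor set by the limit of > 40000 nM in this assay, at which 2 of the 3 values shown sit. Compound 4 `CCN(CC)c1ccc2cc(C(=O)c3ccc(N4CCN(C(=O)CN5CCN(CC(C)=O)CC5)CC4)cc3)oc2c1` differs from compound 3 by acetyl in place of ethynyl on a saturated chain carbon bound to an amine nitrogen in a ring. Among the measured compounds shown here, no measured step touches this part of the shared core, so the single step measured gives no guide to direction, and a value at the limit once more appears the most likely result. Compound 4 is therefore expected to give about 45000 nM, within 20000 nM to 100000 nM. The expected step that the limit leaves unreadable from compound 3 to compound 4 is estimated to stay within the scatter.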

Compound 4, half-maximal inhibitory concentration: 2760 nM
Estimate against measurement, compound 4: 16-fold (1.21 log units) above; the measured number lies below the stated range.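

At this position on the shared core, the group clearly matters: acetyl in place of ethynyl gives an at least 14-fold lower number from compound 3 to compound 4 (1.16 log units; beyond the scatter), the only step shown that lies beyond the scatter. The value of compound 3, > 40000 nM, is a limit of the assay and not a number. The true step could therefore be larger than this floor, which is set by a limit shared with another compound: the limit of > 40000 nM in this assay, at which 2 of the 4 values shown sit.

The compounds shown do not tell whether the carbonyl oxygen of the acetyl group is what matters. They also leave open how an amine, a carboxylic acid or a longer chain ending in a ketone would behave at this position.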